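Bromo to chloro on the ring: a small step expected

The source may report more compounds than this note shows. Statements on the series, on what has been measured and on what is new or still open speak of the compounds shown alone.

Three compounds share one core. In an assay for binding affinity to adenosine receptor A1 (Bos taurus) (on this read-out lower numbers stand for stronger inhibition and higher numbers for weaker inhibition), compound 1 `CCn1c(=O)c2nc(-c3cccc(S(=O)(=O)O)c3)[nH]c2n(CC)c1=O` gives 8420 nM, compound 2 `C=CCn1c(=O)c2[nH]c(-c3ccc(Cl)cc3N)nc2n(C)c1=O` gives 2 nM, and compound 3 `Cn1c(=O)c2nc(-c3ccc(Br)cc3)[nH]c2n(C)c1=O` gives 0.75 nM. Compound 3 shows the lowest number of the three: compound 2 lies nearest to it, yet already beyond the usual scatter, while compound 1 lies far above.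

Compound 4 `Cn1c(=O)c2nc(-c3ccc(Cl)cc3)[nH]c2n(C)c1=O` differs from compound 3 in a single place: chloro in place of bromo on an aromatic carbon. Exchanging one halogen for another of this kind usually moves the number little, so compound 4 is expected to stay close to compound 3, with a step of a 1.6-fold higher number from compound 3 to compound 4 (0.20 log units; within the scatter) that lies within the usual scatter or points only slightly toward a higher number. In this assay compound 4 is estimated at 1.2 nM, with a likely range from 0.4 nM to 4 nM.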

Compound 4, half-maximal inhibitory concentration: 0.8 nM
Compound 4: middle estimate off by 1.5-fold (0.18 log units), on the high side; the measured number falls inside the stated range.
By their numbers in this assay, from the lowest: compounds 3 and 4 (each within the scatter of the next); then compound 2; then compound 1.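

In this assay the change of chloro in place of bromo, on an aromatic carbon para to a large group, gives a 1.1-fold higher number from compound 3 to compound 4 (0.03 log units; within the scatter) and so leaves the number unchanged within the scatter. Among these compounds, this is the first direct reading at this position, as the earlier compounds offered no pair differing in one place. Nothing available here explains why the two halogens match.

Still open, going by these compounds, is whether a smaller halogen such as fluoro, or a methyl, an amine or a carboxylic acid, would be tolerated at this place. A single pair also cannot show how far this position accepts change in general.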